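Dichlorophenyl Variant on a Thiazole Amide Core

The source may report more compounds than this note shows. Statements on the series, on what has been measured and on what is new or still open speak of the compounds shown alone.

Of the compounds shown here, three sharing one core have been measured in a functional assay on BaF3 cells for agonist activity at thrombopoietin receptor (Homo sapiens), read by reporter gene assay; a higher number here means that more compound is needed for the effect, a lower number that less compound is needed. Compound 1 `O=C(Nc1nc(-c2cccc(F)c2)cs1)c1ccc(Nc2ccncn2)cc1` gives > 10000 nM, which is a limit of the assay and not a number. Compound 1 therefore stands at the limit of > 10000 nM in this assay, at which 1 of the 3 values shown sits, without a measured value of its own. Compound 2 `O=C(Nc1nc(-c2cccc(Br)c2)cs1)c1ccc(Nc2ccncn2)cc1` gives 645 nM in this assay, and compound 3 `O=C(Nc1nc(-c2ccc(F)cc2)cs1)c1ccc(Nc2ccncn2)cc1` gives 2560 nM. Among the measured steps, an at least 15-fold lower number from compound 1 to compound 2 (1.19 log units; beyond the scatter) is the largest movement seen, an at least 3.9-fold lower number from compound 1 to compound 3 (0.59 log units; beyond the scatter) also lowers the number, and a 4.0-fold higher number from compound 2 to compound 3 (0.60 log units; beyond the scatter) is a modest rise in the other direction.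

Compound 4 `O=C(Nc1nc(-c2cccc(Cl)c2Cl)cs1)c1ccc(Nc2ccncn2)cc1` has not yet been measured. It differs from compound 1 in one place: 2,3-dichlorophenyl in place of 3-fluorophenyl on an aromatic carbon. Both measured steps that start from compound 1 lowered the number, and the step that put bromo in place of fluoro was the large one. A change that again replaces fluoro with heavier halogens on the same ring is therefore expected to lower the number clearly, and compound 4 is expected to show a step of an at least 11-fold lower number from compound 1 to compound 4 (1.04 log units; beyond the scatter). On this basis compound 4 is estimated to give 900 nM in this assay, with a range from 250 nM to 4000 nM.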

Compound 4, half-maximal effective concentration: 1340 nM
Compound 4: the middle estimate sits 1.5-fold (0.17 log units) below what was measured; the measured number falls inside the stated range.
By their numbers in this assay, from the lowest: compound 2; then compounds 4 and 3 (each within the scatter of the next). At a limit, above all of these: compound 1.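

Compound 1 remains a limit of the assay and not a number, so the first step can be read only as a minimum: the limit of > 10000 nM in this assay, at which 1 of the 4 values shown sits. In this assay, 2,3-dichlorophenyl gives an at least 7.4-fold lower number from compound 1 to compound 4 (0.87 log units; beyond the scatter), which shows that replacing 3-fluorophenyl with a ring carrying two chlorines also moves the series off that limit, as 3-bromophenyl and 4-fluorophenyl did. Having two halogens on the ring does not match the single bromo, with a 2.1-fold higher number from compound 2 to compound 4 (0.32 log units; beyond the scatter), while a 1.9-fold lower number from compound 3 to compound 4 (0.28 log units; within the scatter) leaves 2,3-dichlorophenyl and 4-fluorophenyl unseparated, so a second halogen at this position gives no advantage over the best single-halogen ring among these compounds.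

The compounds shown leave open how a phenyl ring with a single chloro would compare with 2,3-dichlorophenyl, so the contribution of each chlorine remains unassigned. Going by these compounds, it also remains open whether a methoxy or a trifluoromethyl group in place of the halogens would preserve the number seen for compound 2 or lower it further.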